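The source may hold more compounds than are shown below. What is called first, only, known or untested is meant among the compounds shown, and "the series" means these compounds.

Three hydrazides sharing the same dichloropyridine core have been measured in a functional assay on HEK293 cells for antagonist activity at P2X purinoceptor 7 (Homo sapiens), read by fluorescence, with a stated time of 2 h; on this read-out lower numbers stand for stronger inhibition and higher numbers for weaker inhibition. Compound 1 `O=C(CCc1ccccc1)NNc1c(Cl)cncc1Cl` gives 650 nM, compound 2 `O=C(CCCc1ccccc1)NNc1c(Cl)cncc1Cl` gives 770 nM, and compound 3 `O=C(CCCCc1ccccc1)NNc1c(Cl)cncc1Cl` gives 1200 nM. Each extension of the chain changed little: a 1.2-fold higher number from compound 1 to compound 2 (0.07 log units; within the scatter) and a 1.6-fold higher number from compound 2 to compound 3 (0.19 log units; within the scatter). Compound 3 thus shows the highest number of the three, yet its gaps to compound 2 and compound 1 both sit within the scatter. Compound 4 `O=C(CCCC1CCCCC1)NNc1c(Cl)cncc1Cl` differs from compound 3 by cyclohexyl in place of benzyl on a saturated chain carbon, three bonds along the chain from a carbonyl carbon. Among the compounds with values here, no measured step exchanges an aromatic ring for a saturated one, so only the flat chain-length steps inform the expectation, and a modest weakening is estimated, a 1.5-fold higher number from compound 3 to compound 4 (0.18 log units; within the scatter). Compound 4 is therefore expected to give about 1800 nM in this assay, within 600 nM to 5500 nM.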

Compound 4, half-maximal inhibitory concentration: 360 nM
Compound 4: middle estimate off by 5.0-fold (0.70 log units), on the high side, outside the stated range (below it).
By their numbers in this assay, from the lowest: compounds 4, 1, 2 and 3 (each within the scatter of the next, the first and the last beyond it).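

Within the data shown here, at the saturated chain carbon, three bonds along the chain from a carbonyl carbon, cyclohexyl in place of benzyl is the first single change in this assay to pass the scatter (a 3.3-fold lower number from compound 3 to compound 4 (0.52 log units; beyond the scatter)). Cyclohexyl in place of phenyl at that carbon also passes it (a 2.1-fold lower number from compound 2 to compound 4 (0.33 log units; beyond the scatter)), whereas the comparison with the shortest chain does not (a 1.8-fold lower number from compound 1 to compound 4 (0.26 log units; within the scatter)). Nothing available explains the difference between the two rings. On these data alone, whether cyclohexyl gives the same step on the shorter chain of compound 1 remains open. So does the outcome with a cyclopentyl or piperidine ring at this place.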